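Compound 3 to Compound 4: Weighing a Chain Change

A few compounds are considered here, and "the series" means these few. Any claim that something is new, unique, unknown or untested is made for them only; others in the source may bear on it.

compound 1, `O=C(NCC(O)CO)c1cc2cc(Cl)ccc2oc1=O`: 23%
compound 2, `COc1cccc2c1OC(C)(O)C(C(C)=O)=C2`: 24%
compound 3, `COCCNC(=O)c1cc2cccc(OC)c2oc1=N`: 43%

Of the compounds shown here, three have been measured in an assay on HEK293 cells for displacement of a labelled ligand from adenosine receptor A2b (Homo sapiens), read by scintillation counting, with a stated time of 30 min, tested at 10 uM; a higher number here means more inhibition at the concentration tested (going by the name of the read-out), a lower number less inhibition. Among them compound 3 stands highest. The nearest to it is compound 2, whose number lies lower by a gap that is beyond the usual scatter, and the furthest is compound 1, whose number lies lower by a gap that is also beyond the scatter. Compound 3 is therefore the only one of the three that clears the others by more than the scatter.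

The unmeasured compound 4, `COc1cccc2cc(C(=O)NCCCCCO)c(=N)oc12`, differs from compound 3 in one place: 3-hydroxypropyl in place of methoxy on a saturated chain carbon, two bonds along the chain from an amide-type nitrogen. The place of the change is on a saturated chain carbon, two bonds along the chain from an amide-type nitrogen.

Going by the values given here, no pair of measured compounds shows this kind of change, so there is no step on record to guide the size. With the core and the amide left as they are, a small step in this assay is expected, most likely downward but not clearly beyond the scatter; the expected step from compound 3 to compound 4 is a number 6 percentage points lower from compound 3 to compound 4 (within the scatter). For compound 4 the estimate in this assay is 37%, within a range from 20% to 54%.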

Compound 4, a percentage reported as inhibition, at one concentration (the size of the read-out at that concentration, not a potency): > 70%
Compound 4: a limit, no number; the forecaster's own chance of this, stated with the estimate: 0%; at least 33 percentage points between middle value and limit.
By their numbers in this assay, from the lowest: compounds 1 and 2 (each within the scatter of the next); then compound 3. At a limit, above all of these: compound 4.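

In this assay compound 4 gives > 70%, which is a limit of the assay and not a number. Going by these compounds alone, with the core and the amide left as they are, the exchange of methoxy for 3-hydroxypropyl on a saturated chain carbon, two bonds along the chain from an amide-type nitrogen, comes out as a number at least 27 percentage points higher from compound 3 to compound 4 (beyond the scatter), so this place on the chain, about which the earlier compounds showed nothing, can move the read-out by more than the scatter through this one change. The full size of the step remains unread, and what is known of it rests on the limit: the limit of > 70% in this assay, at which 1 of the 4 values shown sits.

The compounds shown do not separate the added chain length from the hydroxy group, since the two enter together in this single step. From the compounds shown here alone, whether a plain pentyl chain, or an amine or a carboxylic acid in place of the hydroxy group, would keep the read-out at this level remains open.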